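Compound 3 to compound 4: a shorter group on the core

A few compounds are considered here, and "the series" means these few. Any claim that something is new, unique, unknown or untested is made for them only; others in the source may bear on it.

Measured in a functional assay on MCF7 cells (Homo sapiens) for antiproliferative activity, read by MTT assay, with a stated time of 72 h (a lower number here means a stronger inhibitor, a higher number a weaker inhibitor), so far:
- compound 1 (`CCN1CCN(c2cc(C)c3cc(NC(=O)c4ccc(C)cc4)ccc3n2)CC1`) gives 6740 nM
- compound 2 (`CCN1CCN(c2cc(C)c3cc(NC(=O)c4cccc(C)c4)ccc3n2)CC1`) gives 7800 nM
- compound 3 (`Cc1cc(NCCN(C)C)nc2ccc(NC(=O)c3ccc(Cl)c(Cl)c3)cc12`) gives 2550 nM

Compound 3 has the lowest number of the three, and its gaps to compound 1 and compound 2 lie beyond the scatter. Compound 4 (`Cc1cc(N(C)C)nc2ccc(NC(=O)c3ccc(Cl)c(Cl)c3)cc12`) is still unmeasured. It carries dimethylamino in place of (2-(dimethylamino)ethyl)amino on an aromatic carbon, next to the ring nitrogen (dimethylamino in place of (2-(dimethylamino)ethyl)amino on an aromatic carbon).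

Going by the values given here, the one measured step (a 1.2-fold higher number from compound 1 to compound 2 (0.06 log units; within the scatter)) lies within the scatter, but it concerns a different place, so it gives no direct guide here. Among the compounds with values here, no measured pair isolates this change, and compound 1 and compound 2 differ from compound 3 in more than one place. The expectation rests only on compound 3 (2550 nM) standing lowest of the three, so a move towards the other values is expected. The estimated step is modest and towards a higher number (a 2.0-fold higher number from compound 3 to compound 4 (0.29 log units; within the scatter)) with wide uncertainty. For compound 4 the value in this assay is estimated at 5000 nM within an expected range (1800 nM to 15000 nM).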

Compound 4, half-maximal inhibitory concentration: 33300 nM
Compound 4: the middle estimate sits 6.7-fold (0.82 log units) below what was measured; measured number outside the range, above it.
By their numbers in this assay, from the lowest: compound 3; then compounds 1 and 2 (each within the scatter of the next); then compound 4.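

In this assay, dimethylamino in place of (2-(dimethylamino)ethyl)amino on the aromatic carbon next to the ring nitrogen gives a 13-fold higher number from compound 3 to compound 4 (1.12 log units; beyond the scatter), a large step beyond the scatter. Going by these compounds alone, this is the first measured change at this position, and it shows that the number responds strongly to the group here, whereas the only earlier step, at the carbonyl-bound methylphenyl, stayed within the scatter. Within the data shown here, the single change removes the chain's amine hydrogen-bond donor and its end dimethylamino together with part of its length, and no measurement on hand explains the step.

Which of these differences carries the step remains open. A methylamino group, a 2-methoxyethylamino chain or a longer 3-(dimethylamino)propylamino chain on this carbon, with the rest of compound 3 unchanged, would help to separate them.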